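Swapping Bromo for Methyl: From Compound 2 to Compound 4

A few compounds are considered here, and "the series" means these few. Any claim that something is new, unique, unknown or untested is made for them only; others in the source may bear on it.

Measured compounds:
compound 1 `COc1ccc(CNc2cc(OC)c(OC)c(OC)c2)cc1[N+](=O)[O-]` gives 19400 nM
compound 2 `COc1ccc(CN(C(=O)C(C)Br)c2cc(OC)c(OC)c(OC)c2)cc1O` gives 120 nM
compound 3 `COC(=O)c1cc(CNc2cc(OC)c(OC)c(OC)c2)ccc1OC` gives 49600 nM

In a functional assay on MGC-803 cells (Homo sapiens) for inhibition, read by MTT assay, with a stated time of 48 h (a higher number here means a weaker inhibitor, a lower number a stronger inhibitor), compound 2 stands lowest of the three numbers, far below compound 1 and compound 3. Compound 4 `COc1ccc(CN(C(=O)C(C)C)c2cc(OC)c(OC)c(OC)c2)cc1O` is not yet measured; it differs from compound 2 by methyl in place of bromo on a saturated chain carbon bound to a carbonyl carbon and a saturated chain carbon. For the measured compounds named here, the only measured step, a 2.6-fold higher number from compound 1 to compound 3 (0.41 log units; beyond the scatter), concerns a change elsewhere on the shared core and says nothing about this one, so no measured pair bears on it directly. Without such guidance, a weaker result is expected for compound 4, with wide uncertainty: the estimate is 4000 nM, ranging from 600 nM to 30000 nM. This expected step, a 33-fold higher number from compound 2 to compound 4 (1.52 log units; beyond the scatter), is a guess rather than an extrapolation.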

Compound 4, half-maximal inhibitory concentration: 210 nM
Estimate against measurement, compound 4: 19-fold (1.28 log units) above, and the stated range ends above it.
By their numbers in this assay, from the lowest: compounds 2 and 4 (each within the scatter of the next); then compound 1; then compound 3.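

Putting methyl in place of bromo gives, in this assay, a 1.8-fold higher number from compound 2 to compound 4 (0.24 log units; within the scatter), so the two numbers cannot be told apart. Bromo is therefore not required on this saturated chain carbon for a number in this range, since the isopropylcarbonyl group of compound 4 serves as well as the (1-bromoethyl)carbonyl group of compound 2. No measurement available here explains why the two groups read alike. Still open, on these data alone, is how much else this carbon tolerates: whether an amine, a carboxylic acid or a longer chain in the same place would keep the number in this range.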